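This account rests on a few compounds, and the source may have more. Where it says the series, first, only, none or still open, it means among the compounds named here.

Among the measured compounds shown here, compound 2, `Cc1nc(C)n(CC(=O)N2CCN(c3sc(C(F)(F)F)nc3-c3nc4ccc(C5CCOCC5)cc4[nH]3)C[C@H]2C)n1`, stands at the top of the two numbers measured so far in a physicochemical assay for lipophilicity, at pH 7.4; on this read-out higher numbers stand for higher lipophilicity and lower numbers for lower lipophilicity: compound 2 gives 3.7, whereas compound 1, `C[C@@H]1CN(c2sc(C(F)(F)F)nc2-c2nc3cc(OCCO)ccc3[nH]2)CCN1C(=O)Cn1cnc2cccnc21`, gives 2.4 in this assay, a gap beyond the scatter. Compound 3, `Cc1nc(C)n(CC(=O)N2CCN(c3sc(C(F)(F)F)nc3-c3nc4ccc(C5CCN(C)CC5)cc4[nH]3)C[C@H]2C)n1`, has not yet been measured. It differs from compound 2 in one place: 1-methylpiperidin-4-yl in place of oxan-4-yl on an aromatic carbon. For the measured compounds named here, no measured pair shows this change, so its effect is unknown here. A step downward in this assay beyond the scatter is expected, of the size a number 1.40 log units lower from compound 2 to compound 3 (beyond the scatter). Compound 3 is accordingly estimated at 2.3, between 1.6 and 3.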

Compound 3, distribution coefficient: 3.4
The estimate for compound 3 lay 1.10 log units below the measured number; the whole stated range lies below it.
By their numbers in this assay, from the lowest: compound 1; then compounds 3 and 2 (each within the scatter of the next).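

On the aromatic carbon of the shared core, placing 1-methylpiperidin-4-yl where oxan-4-yl stood gives, in this assay, a number 0.30 log units lower from compound 2 to compound 3 (within the scatter). Among the compounds shown here, this is the first measured pair at this position, and with this one pair the two six-membered rings cannot be told apart on this read-out. No evidence is available here to account for this result.

Going by these compounds, what remains open is whether an open-chain amine or a carboxylic acid on this aromatic carbon would stand apart from these two rings. Also open, on these data alone, is whether this same exchange would read alike with a different group elsewhere on the shared core.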